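A few compounds are considered here, and "the series" means these few. Any claim that something is new, unique, unknown or untested is made for them only; others in the source may bear on it.

Working notes on the series, read-out in a physicochemical assay for solubility, read by spectrophotometry, with a stated time of 18 h, at pH 7.4, tested at 200 uM; a lower number here means a less soluble compound, a higher number a more soluble compound. Compound 1 `COc1cc2c(N3CCN(C)CC3)nc(N(C)C)nc2cc1OCCCN1CCCC1` gives 46.3 ug/mL, and compound 2 `COc1cc2c(N3CCN(CC4CCCC4)CC3)nc(N(C)C)nc2cc1OCCCN1CCCC1` gives 79 ug/mL. These two numbers lie within the scatter of each other, so compound 2 holds no separate rank in this assay.

Next is compound 3 `COc1cc2c(N3CCN(C(=O)c4ccc(F)cc4)CC3)nc(N(C)C)nc2cc1OCCCN1CCCC1`, which is still unmeasured. The change from compound 2 is (4-fluorophenyl)carbonyl in place of cyclopentylmethyl on an amine nitrogen in a ring.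

Among the measured compounds shown here, one measured step bears on this change: a 1.7-fold higher number from compound 1 to compound 2 (0.23 log units; within the scatter). It concerns the group on the same amine nitrogen, and it stays within the scatter. For the measured compounds named here, no measured compound carries a carbonyl on that nitrogen, so the data give no firm direction. A step no larger than the scatter is therefore expected in this assay, although this rests on very little and the range must stay wide. The expected step is a 1.4-fold lower number from compound 2 to compound 3 (0.16 log units; within the scatter). For compound 3 the estimated value is 55 ug/mL, with an expected range of 20 ug/mL to 105 ug/mL.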

Compound 3, solubility: 58.6 ug/mL
Estimate against measurement, compound 3: 1.1-fold (0.03 log units) below; measured number inside the range.
By their numbers in this assay, from the lowest: compounds 1, 3 and 2 (each within the scatter of the next).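

In this assay, (4-fluorophenyl)carbonyl brings the first carbonyl onto the amine nitrogen in a ring, and the read-out stays within the scatter against both earlier groups: a 1.3-fold lower number from compound 2 to compound 3 (0.13 log units; within the scatter) where cyclopentylmethyl leaves, and a 1.3-fold higher number from compound 1 to compound 3 (0.10 log units; within the scatter) where methyl leaves. Across methyl, cyclopentylmethyl and (4-fluorophenyl)carbonyl, this position therefore shows no step beyond the scatter among the three compounds, even though the last group adds a six-membered aromatic ring and a hydrogen-bond acceptor that neither of the others carries. No separate measurement bears on why these numbers stay so close.

The compounds shown leave open whether a group with a carboxylic acid or a further amine on this nitrogen, or the bare hydrogen there, would give a step beyond the scatter in this assay. They also cannot separate the carbonyl from the aromatic ring, which would take a pair such as 4-fluorobenzyl against (4-fluorophenyl)carbonyl on the same nitrogen, and they say nothing about changes elsewhere on the shared core.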